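Methyl on the aminocyanopyrimidine: an expected stability read-out

The source may report more compounds than this note shows. Statements on the series, on what has been measured and on what is new or still open speak of the compounds shown alone.

Of the compounds shown here, two sharing one core have been measured in an ADME assay on microsomes from liver (Rattus norvegicus), read by LC-MS, using NADPH, with a stated time of 30 min, tested at 1 uM; on this read-out higher numbers stand for a more stable compound and lower numbers for a less stable compound. Compound 1 `Cc1c(F)ccc2cc([C@H](C)Nc3ncnc(N)c3C#N)c(-c3ccccc3)c(=O)n12` gives 90% in this assay. Compound 2 `C[C@H](Nc1nc(N)ncc1C#N)c1cc2ccc(F)cn2c(=O)c1-c1ccccc1` gives 74% in this assay, the lower of the two numbers, and its gap to compound 1 lies beyond the usual scatter. Compound 3 `Cc1nc(N)nc(N[C@@H](C)c2cc3ccc(F)cn3c(=O)c2-c2ccccc2)c1C#N` differs from compound 2 by methyl in place of hydrogen on an aromatic carbon. Going by the values given here, no measured pair shows this change, so the expected step of a number 2 percentage points lower from compound 2 to compound 3 (within the scatter) is small, with no clear direction beyond the scatter. In this assay compound 3 is therefore estimated at 72%, within a range from 50% to 90%.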

Compound 3, percent of the compound remaining: 41%
The estimate for compound 3 lay 31 percentage points above the measured number; the measured number lies below the stated range.
By their numbers in this assay, from the lowest: compound 3; then compound 2; then compound 1.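

In this assay, a single methyl on the aromatic carbon next to the ring nitrogen and ortho to the cyano group is far from a neutral addition: the number falls a number 33 percentage points lower from compound 2 to compound 3 (beyond the scatter). This position therefore responds strongly to the change from 2-amino-5-cyanopyrimidin-4-yl to 2-amino-5-cyano-6-methylpyrimidin-4-yl. Nothing available bears on why the number falls. As far as these compounds go, whether an ethyl chain, a methoxy group or a chlorine atom on this carbon would give a similar number remains open. From the compounds shown here alone, it is also open whether methyl would act alike on the core of compound 1.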